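Compound 3: what is expected when the thiophene ester is replaced?

This account rests on a few compounds, and the source may have more. Where it says the series, first, only, none or still open, it means among the compounds named here.

compound 1 `C=C1CC[C@@H]2[C@](C)(COC(=O)c3cccnc3)[C@H](O)CC[C@@]2(C)[C@@H]1/C=C/C1=CCOC1=O`: 113000 nM
compound 2 `C=C1CC[C@@H]2[C@](C)(COC(=O)c3cccs3)[C@H](O)CC[C@@]2(C)[C@@H]1/C=C/C1=CCOC1=O`: 557000 nM

In an ADME assay on HepG2 2.2.15 cells (Homo sapiens) for cytotoxicity, read by MTT assay (a lower number here means that less compound is tolerated, a higher number that more compound is tolerated), compound 2 gives the higher of the two numbers, 557000 nM. Compound 3 `C=C1CC[C@@H]2[C@](C)(C=O)[C@H](O)CC[C@@]2(C)[C@@H]1/C=C/C1=CCOC1=O` carries formyl in place of (((thiophen-2-yl)carbonyl)oxy)methyl on a saturated ring carbon. Within the data shown here, only one measured step bears on this, a 4.9-fold higher number from compound 1 to compound 2 (0.69 log units; beyond the scatter), and it is modest. That step swapped only the ring on the carbonyl carbon, so it is a rough guide to removing the whole group. A modest move toward a lower number is expected, the estimated step being a 2.8-fold lower number from compound 2 to compound 3 (0.44 log units; beyond the scatter). The expected value for compound 3 is 200000 nM, with an estimated range from 50000 nM to 700000 nM.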

Compound 3, half-maximal cytotoxic concentration: 122000 nM
Estimate against measurement, compound 3: 1.6-fold (0.21 log units) above; measured number inside the range.
By their numbers in this assay, from the lowest: compounds 1 and 3 (each within the scatter of the next); then compound 2.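

In this assay the step is a 4.6-fold lower number from compound 2 to compound 3 (0.66 log units; beyond the scatter) when formyl replaces (((thiophen-2-yl)carbonyl)oxy)methyl on the saturated ring carbon. The same replacement of (((pyridin-3-yl)carbonyl)oxy)methyl gives a 1.1-fold higher number from compound 1 to compound 3 (0.03 log units; within the scatter) and so makes no real difference. At this position, then, the thiophene ester stands apart, while the pyridine ester and the much smaller formyl cannot be told apart. Nothing available explains why the two esters differ. Going by these compounds, it remains open whether a benzoate ester, a hydroxymethyl group or a carboxylic acid here would match compound 2 or compound 3.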